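The compounds below may be only part of what the source reports. "The series", "measured", "known", "first", "only" and "open" are said of these compounds alone.

Working notes on the series in an ADME assay on BJ cells (Homo sapiens) for cytotoxicity, with a stated time of 72 h; a lower number here means that less compound is needed, a higher number that more compound is needed for the effect. Compound 1 (`Cc1ccc(NC(=O)Nc2cc(C)nc3ccccc23)cc1`) reads > 25000 nM in this assay, which is a limit of the assay and not a number. Compound 2 (`Cc1cc(NC(=O)Nc2ccc(F)c(F)c2)c2ccccc2n1`) reads > 25000 nM, and this too is a limit. Going by the values given here, the series so far therefore rests on (the limit of > 25000 nM in this assay, at which 2 of the 2 values shown sit), and compound 2 has no numerical reading.

Compound 3 (`Cc1cc(NC(=O)Nc2cccc(F)c2)c2ccccc2n1`) differs from compound 2 by hydrogen in place of fluoro on an aromatic carbon. Among the compounds with values here, no step between measured compounds is available to size this change. In this assay, no shift beyond the usual scatter is expected. This expectation rests on compound 2, with its limit reading of > 25000 nM. The expected step, a step that the limit leaves unreadable from compound 2 to compound 3, is therefore only a nominal estimate. The reading for compound 3 is expected to be, most likely, a limit again. For compound 3 the estimated value is 28000 nM, with an expected range from 14000 nM to 50000 nM.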

Compound 3, half-maximal effective concentration: > 25000 nM
Compound 3 was reported as a limit (the forecaster's own chance of this, stated with the estimate: 85%); the middle value lies beyond the limit too.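

No step can be read from the new result: compound 3 gives > 25000 nM in this assay, again a limit and not a number, so its steps from compound 1 and compound 2 cannot be read. The series rests entirely on one reading: the limit of > 25000 nM in this assay, at which 3 of the 3 values shown sit.

What the compounds shown leave open is which change in this series, if any, would bring a numerical reading in this assay.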